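This account rests on a few compounds, and the source may have more. Where it says the series, first, only, none or still open, it means among the compounds named here.

Going by the values given here, compound 2 `Oc1cc(C(F)(F)F)ccc1-c1nc(-c2ccccc2O)n(-c2cccc(C(F)(F)F)c2)n1` gives 71.5% in a functional assay on PC-12 cells (Rattus norvegicus) for cytotoxicity, read by MTT assay, with stated times of 2 h and 24 h, tested at 1 uM (on this read-out higher numbers stand for a stronger effect at the one concentration tested and lower numbers for a weaker effect), the higher of the two numbers so far; compound 1 `Oc1cc(C(F)(F)F)ccc1-c1nc(-c2ccccc2O)n(-c2ccccc2F)n1` gives 63.4%, and the step of a number 8.1 percentage points higher from compound 1 to compound 2 (within the scatter) lies within the scatter. Compound 3 `Cc1ccc(-n2nc(-c3ccc(C(F)(F)F)cc3O)nc2-c2ccccc2O)c(C)c1` differs from compound 2 in one place: 2,4-dimethylphenyl in place of 3-(trifluoromethyl)phenyl on an aromatic nitrogen. Among the compounds with values here, the only step at the same place, a number 8.1 percentage points higher from compound 1 to compound 2 (within the scatter), was small, so a change at this aromatic nitrogen is expected to shift the read-out little, if at all. Compound 3 is therefore expected near 67%, between 54% and 80%, meaning a step of a number 4.5 percentage points lower from compound 2 to compound 3 (within the scatter).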

Compound 3, a percentage reported as activity, at one concentration (the size of the read-out at that concentration, not a potency): 73.7%
Estimate against measurement, compound 3: 6.7 percentage points below; the range from low to high includes it.
By their numbers in this assay, from the lowest: compounds 1, 2 and 3 (each within the scatter of the next, the first and the last beyond it).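

In this assay, 2,4-dimethylphenyl, which holds no fluorine, replaces 3-(trifluoromethyl)phenyl on the aromatic nitrogen with a number 2.2 percentage points higher from compound 2 to compound 3 (within the scatter), so among these compounds the read-out at this position does not depend on fluorine in the group. Set against 2-fluorophenyl, the same group gives a number 10.3 percentage points higher from compound 1 to compound 3 (beyond the scatter), the first step at this position to pass the scatter, and only modestly. Nothing shown explains either step. Going by these compounds, all three compounds carry a substituted phenyl group here, so the effect of a longer chain on this nitrogen, or of an amine or a carboxylic acid on the phenyl ring, remains open.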